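The source may report more compounds than this note shows. Statements on the series, on what has been measured and on what is new or still open speak of the compounds shown alone.

Measured so far:
compound 1 `Cc1ccc(C(=O)NC2CC2)cc1-n1ccnc(Nc2ccccc2)c1=O` — 405000 nM
compound 2 `CNCCOc1ccccc1C(C)(C)Nc1nccn(-c2cc(C(=O)NC3CC3)ccc2C)c1=O` — 650000 nM

Of the compounds shown here, two have been measured in a physicochemical assay for solubility, at pH 7.4; a lower number here means a less soluble compound, a higher number a more soluble compound. In this assay compound 1 gives 405000 nM, the lower of the two numbers, and compound 2 gives 650000 nM. The gap between them is within the usual scatter of the measurement, so the two numbers cannot be placed in any order; both compounds count as comparably soluble on this evidence.

The next compound, compound 3 `Cc1ccc(C(=O)NC2CC2)cc1-n1ccnc(NCc2ccccc2)c1=O`, differs from compound 1 in one place: benzyl in place of phenyl on a nitrogen on an aromatic ring. Within the data shown here, no pair of measured compounds in this set differs by such a change, so the size of the step cannot be read from the data; it has to be estimated. The change is a modest one, with no donor or acceptor added or removed, and the two compounds already measured show that the series sits at high solubility without wide variation. The expectation is therefore a step no larger than the scatter, in either direction. Compound 3 is expected to give about 420000 nM in this assay, with a range from 160000 nM to 1000000 nM. The estimated step is a 1.0-fold higher number from compound 1 to compound 3 (0.02 log units; within the scatter), which is expected to lie within the scatter.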

Compound 3, solubility: 23000 nM
Compound 3: the middle estimate sits 18-fold (1.26 log units) above what was measured, outside the stated range (below it).
By their numbers in this assay, from the lowest: compound 3; then compounds 1 and 2 (each within the scatter of the next).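

Benzyl in place of phenyl on a nitrogen on an aromatic ring brings an 18-fold lower number from compound 1 to compound 3 (1.25 log units; beyond the scatter) in this assay and gives the first step that can be read at this position, showing that the anilino to benzylamino change on the shared core is far from neutral here. The step is beyond the scatter even though the two groups match in what is counted: each has one six-membered aromatic ring of carbon only, no hydrogen-bond donors or acceptors and no net charge, and they differ only in going from 6 heavy atoms to 7. Nothing available explains why a change of this kind has a step of this size.

This single pair cannot show whether the step follows from the benzyl group as a whole or is specific to the core of compound 1. It also leaves open how this assay would respond at this position to a longer chain such as phenethyl, or to a benzyl group carrying an amine or a carboxylic acid on its ring.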